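Moving the nitro group on the benzyl ether of a flavonol

The compounds below may be only part of what the source reports. "The series", "measured", "known", "first", "only" and "open" are said of these compounds alone.

Within the data shown here, compound 2 `Cc1ccccc1COc1cc(O)c2c(=O)c(O)c(-c3ccccc3)oc2c1` gives 17000 nM in an ADME assay on Huh-5-2 cells (Homo sapiens) for cytotoxicity, read by WST assay, with a stated time of 3 days (on this read-out lower numbers stand for higher toxicity in this test and higher numbers for lower toxicity in this test), the lowest of the two numbers so far, with compound 1 `O=c1c(O)c(-c2ccccc2)oc2cc(OCc3ccccc3[N+](=O)[O-])cc(O)c12` giving 32000 nM in this assay. The step of a 1.9-fold lower number from compound 1 to compound 2 (0.27 log units; within the scatter) bears on the present change, since compound 3 `O=c1c(O)c(-c2ccccc2)oc2cc(OCc3cccc([N+](=O)[O-])c3)cc(O)c12` differs from compound 2 by 3-nitrophenyl in place of 2-methylphenyl on a saturated chain carbon bound to an oxygen on an aromatic ring. That earlier exchange of nitro for methyl stayed within the scatter, so he expects no step beyond the scatter here either, that is a 1.5-fold higher number from compound 2 to compound 3 (0.17 log units; within the scatter). His estimate for compound 3 in this assay is 25000 nM, with a range from 10000 nM to 60000 nM.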

Compound 3, half-maximal cytotoxic concentration: 76000 nM
Compound 3: the middle estimate sits 3.0-fold (0.48 log units) below what was measured; the whole stated range lies below it.
By their numbers in this assay, from the lowest: compounds 2 and 1 (each within the scatter of the next); then compound 3.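

In this assay the place of the nitro group counts: 3-nitrophenyl in place of 2-nitrophenyl gives a 2.4-fold higher number from compound 1 to compound 3 (0.38 log units; beyond the scatter), a move towards lower toxicity in this test that the within-scatter exchange of nitro for methyl had not revealed. Against 2-methylphenyl, the same group gives a 4.5-fold higher number from compound 2 to compound 3 (0.65 log units; beyond the scatter), so only the 3-nitrophenyl compound stands apart from both others. Nothing given here accounts for this difference. On these data alone, whether an amine or a carboxylic acid in place of the nitro group would keep this higher number remains open.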